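Notes on the series: 4-fluorophenyl to 4-methoxyphenyl

This account rests on a few compounds, and the source may have more. Where it says the series, first, only, none or still open, it means among the compounds named here.

In a functional assay on HeLa cells (Homo sapiens) for antiproliferative activity, read by MTT assay, with a stated time of 48 h (on this read-out lower numbers stand for stronger inhibition and higher numbers for weaker inhibition), compound 1 (`Cn1cc(-c2cnc3ccc(NCC4CC4)nc3c2)cn1`) gives > 50000 nM as a limit of the assay and not as a number. In this assay, for the measured compounds named here, compound 2 (`Cn1cc(-c2cnc3ccc(NCc4ccc(F)cc4)nc3c2)cn1`) gives 46600 nM as the only actual number so far. Going by the values given here, the single measured step (an at least 1.0-fold lower number from compound 1 to compound 2 (0.03 log units; that floor lies within the scatter)) stays within the scatter at its floor and concerns a different group on the chain.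

Compound 3 (`COc1ccc(CNc2ccc3ncc(-c4cnn(C)c4)cc3n2)cc1`) changes 4-fluorophenyl to 4-methoxyphenyl (methoxy in place of fluoro on an aromatic carbon), with methoxy in place of fluoro on an aromatic carbon, para to a large group. Among the compounds with values here, no measured step touches that place, so the series offers no direction for this change. With compound 2 at 46600 nM as the sole anchor, no shift beyond the scatter is expected in this assay. For compound 3 a report at the limit of the assay would not be a surprise. The estimated step (a 1.0-fold lower number from compound 2 to compound 3 (0.02 log units; within the scatter)) carries no direction of its own. For compound 3 the estimated value is 45000 nM with an expected range from 22000 nM to 85000 nM on this read-out.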

Compound 3, half-maximal inhibitory concentration: > 50000 nM
Compound 3 was reported as a limit; the forecaster's own chance of this, stated with the estimate: 40%; at least 1.1-fold (0.04 log units) between middle value and limit.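

Methoxy in place of fluoro on an aromatic carbon, para to a large group, is the first change at this place, and in this assay it gives an at least 1.0-fold higher number from compound 2 to compound 3 (0.03 log units; that floor lies within the scatter). Compound 3 gives > 50000 nM, which is a limit of the assay and not a number. The floor of that step lies within the scatter, so neither this place nor this change gains a readable direction, the step between the two limits cannot be read, and compound 2 remains the only compound with an actual number in the series: the limit of > 50000 nM in this assay, at which 2 of the 3 values shown sit.

Going by these compounds, what an amine or a carboxylic acid in place of methoxy on this aromatic carbon would give in this assay remains open. Also open, on these data alone, is whether a longer chain carrying the 4-fluorophenyl group on the nitrogen of the shared core would give a number clearly apart from that of compound 2.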